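Hydroxyalkyl chain shortening from compound 1 to compound 4

The source may report more compounds than this note shows. Statements on the series, on what has been measured and on what is new or still open speak of the compounds shown alone.

In a functional assay on MCF7 cells (Homo sapiens) for inhibition, read by MTT assay, with a stated time of 4 days (on this read-out higher numbers stand for weaker inhibition and lower numbers for stronger inhibition), compound 1 (`COc1cc(NC(C)CCCNC(=O)NNC(=O)NCCCCCO)c2ncccc2c1`) gives 4000 nM and stands highest of the two numbers available. Compound 2 (`COc1ccc(C(=NNC(=O)NNC(=O)NCCCC(C)Nc2cc(OC)cc3cccnc23)c2ccc(OC)cc2)cc1`) is the nearest neighbour and reads 1000 nM, a lower number, with a gap that lies beyond the scatter. Compound 3 (`CCOC(=O)NC(c1ccccc1)c1ccc(Cl)cc1`) yields only a limit of the assay (> 100000 nM), not a number.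

Compound 4 (`COc1cc(NC(C)CCCNC(=O)NNC(=O)NCCO)c2ncccc2c1`) has not yet been measured. It keeps the core of compound 1 and differs in the side chain: hydroxy in place of 3-hydroxypropyl on a saturated chain carbon, two bonds along the chain from an amide-type nitrogen. Cut one bond further out, the same difference reads 5-hydroxypentyl to 2-hydroxyethyl.

Within the data shown here, no measured pair isolates this chain length. Among the measured compounds shown here, the expectation therefore starts from compound 1 (4000 nM) as the only measured compound with a hydroxy-ended chain. In this assay the expected change is a 1.3-fold higher number from compound 1 to compound 4 (0.10 log units; within the scatter) and no more, a slight lean towards a higher number that is not expected to pass the scatter. For compound 4 the estimate is 5000 nM (expected range 1800 nM to 15000 nM).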

Compound 4, half-maximal inhibitory concentration: 13000 nM
For compound 4 the middle estimate is 2.6-fold (0.41 log units) below the measured one, within the range that was stated.
By their numbers in this assay, from the lowest: compound 2; then compound 1; then compound 4. At a limit, above all of these: compound 3.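

In this assay, among these compounds, the replacement of 5-hydroxypentyl by 2-hydroxyethyl on the core of compound 1 brings a 3.3-fold higher number from compound 1 to compound 4 (0.51 log units; beyond the scatter) and gives the first step that differs in one place. The position, on a saturated chain carbon two bonds along the chain from an amide-type nitrogen, is therefore not indifferent to this change: the shorter hydroxy-ended chain goes with the higher number, although this single step gives only a direction and not a trend with chain length. The groups that leave and enter match in hydrogen-bond donors and acceptors, so the step tracks the loss of chain carbons while the hydroxy end is kept, and nothing measured here gives a cause for it.

Open, from the compounds shown here alone, is the shape of the dependence on chain length, both at an intermediate 3-hydroxypropyl chain and at a longer chain than 5-hydroxypentyl. Also open, going by these compounds, is whether the hydroxy end matters at all, which an unsubstituted alkyl chain, or an amine or a carboxylic acid at the same chain end, would test on the same core.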